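Replacing 5-fluoropyridin-3-yl with 2-methyl-1,3-benzoxazol-5-yl

A few compounds are considered here, and "the series" means these few. Any claim that something is new, unique, unknown or untested is made for them only; others in the source may bear on it.

Measured so far in an ADME assay (liver) for metabolic stability, with Liver microsome (Homo sapiens) as the target, using microsomes and NADPH, with a stated time of 30 min, tested at 1 uM (on this read-out lower numbers stand for slow clearance and higher numbers for fast clearance), on the shared core:
Compound 1 `Nc1ccc(S(=O)(=O)N2CCN(c3ncc(C(O)(C(F)(F)F)C(F)(F)F)cc3-c3ccncc3)CC2)cn1` gives 15 mL.min-1.g-1 in this test
Compound 2 `Nc1ccc(S(=O)(=O)N2CCN(c3ncc(C(O)(C(F)(F)F)C(F)(F)F)cc3-c3cncc(F)c3)CC2)cn1` gives 24 mL.min-1.g-1 in this test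

For the measured compounds named here, compound 2 stands within the scatter of compound 1, the only other measured compound, so the two cannot be ranked. Going by the values given here, the one measured step, a 1.6-fold higher number from compound 1 to compound 2 (0.20 log units; within the scatter), is small.

Compound 3 `Cc1nc2cc(-c3cc(C(O)(C(F)(F)F)C(F)(F)F)cnc3N3CCN(S(=O)(=O)c4ccc(N)nc4)CC3)ccc2o1` has not yet been measured in this assay and keeps the shared core. Among the compounds with values here, its single change is 2-methyl-1,3-benzoxazol-5-yl in place of 5-fluoropyridin-3-yl on an aromatic carbon on an aromatic carbon of the six-membered aromatic ring with 1 nitrogen.

The measured step bears on this only in part. Within the data shown here, it exchanged pyridin-4-yl for 5-fluoropyridin-3-yl, and no measured compound carries a 2-methyl-1,3-benzoxazol-5-yl group. From the compounds shown here alone, the size of a 1.6-fold higher number from compound 1 to compound 2 (0.20 log units; within the scatter) gives no ground to expect a large move, but the new group is untested, so a modest upward step is a weak expectation and the range stays wide.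

The expected change is a 1.3-fold higher number from compound 2 to compound 3 (0.12 log units; within the scatter) in this test. For compound 3 the estimate is 32 mL.min-1.g-1, with an expected range from 13 mL.min-1.g-1 to 75 mL.min-1.g-1 in the same test.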

Compound 3, intrinsic clearance in microsomes: < 14 mL.min-1.g-1
Compound 3: a limit, no number; the forecaster's own chance of this, stated with the estimate: 3%; middle value at least 2.2-fold (0.35 log units) from the limit.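

In this assay compound 3, which carries 2-methyl-1,3-benzoxazol-5-yl on this aromatic carbon, gives < 14 mL.min-1.g-1, and this is a limit of the assay, not a number: the limit of < 14 mL.min-1.g-1 in this assay, at which 1 of the 3 values shown sits.

Until now this place, ortho to a large group and meta to the 2,2,2-trifluoro-1-hydroxy-1-(trifluoromethyl)ethyl group, had held only the single-ring groups pyridin-4-yl and 5-fluoropyridin-3-yl, and the result shows that a group with one five-membered and one six-membered aromatic ring does not carry the read-out above the values of those two. The steps are an at least 1.7-fold lower number from compound 2 to compound 3 (0.23 log units; that floor lies within the scatter) and an at least 1.0-fold lower number from compound 1 to compound 3 (0.02 log units; that floor lies within the scatter), so the limit sets only a floor on each step, and the true size of neither can be read from it.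

The compounds shown leave open whether the methyl group of the new substituent has any share in this result, which a hydrogen or an amine in its place would help to settle. They also leave open whether a different two-ring group, such as an indole or a quinoline, would give a similar read-out at this place.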